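From Nitrile to Methylcarbamoyl: A Small Step Expected

A few compounds are considered here, and "the series" means these few. Any claim that something is new, unique, unknown or untested is made for them only; others in the source may bear on it.

Measured in an assay for binding affinity to 17-beta-hydroxysteroid dehydrogenase type 2 (Homo sapiens), with a stated time of 20 min, tested at 1 uM; on this read-out higher numbers stand for more inhibition at the one concentration tested (going by the name of the read-out) and lower numbers for less inhibition:
compound 1, `Oc1cccc2cc(-c3ccccc3)ccc12`, gives 20%;
compound 2, `Oc1cccc2cc(-c3ccc(F)cc3)ccc12`, gives < 10%;
compound 3, `N#Cc1ccc(-c2ccc3c(O)cccc3c2)cc1`, gives 12%.

Compound 3 holds the lower of the two numbers; its nearest neighbour is compound 1, with a number 8 percentage points lower from compound 1 to compound 3 (within the scatter). For compound 2 the value is a limit of this assay and not a number, as stated by the limit of < 10% in this assay, at which 1 of the 3 values shown sits. Compound 4, `CNC(=O)c1ccc(-c2ccc3c(O)cccc3c2)cc1`, differs from compound 3 by methylcarbamoyl in place of cyano on an aromatic carbon. The steps that touch the same position, a number 8 percentage points lower from compound 1 to compound 3 (within the scatter) and a number at least 2 percentage points higher from compound 2 to compound 3 (that floor lies within the scatter), both stay within the scatter, and none of them involves methylcarbamoyl. The expectation for the step to compound 4 is therefore no change at the digits printed from compound 3 to compound 4 (within the scatter), nothing beyond the scatter. Compound 4 is estimated at 12%, ranging from 0% to 30%.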

Compound 4, a percentage reported as inhibition, at one concentration (the size of the read-out at that concentration, not a potency): 13%
Compound 4: middle estimate off by 1 percentage points, on the low side, and the stated range covers the measured number.
By their numbers in this assay, from the lowest: compounds 3, 4 and 1 (each within the scatter of the next). At a limit, below all of these: compound 2.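

In this assay, this position takes methylcarbamoyl, a group with a hydrogen-bond donor where cyano has none, with no change beyond the scatter: a number 1 percentage points higher from compound 3 to compound 4 (within the scatter). Set against hydrogen at the same place, the group gives a number 7 percentage points lower from compound 1 to compound 4 (within the scatter), so none of the readable steps at this position leaves the scatter. Compound 2 holds a limit and not a number, so the step involving it gives only a floor, a number at least 3 percentage points higher from compound 2 to compound 4 (that floor lies within the scatter): the limit of < 10% in this assay, at which 1 of the 4 values shown sits.

On these data alone, whether an amine, a carboxylic acid or a longer chain on this carbon would move the number beyond the scatter stays open. Changes elsewhere on the shared core also stay open.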